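Methyl on the aniline ring and tolerated concentration

The source may report more compounds than this note shows. Statements on the series, on what has been measured and on what is new or still open speak of the compounds shown alone.

Compound 1 `S=C(Nc1ccccc1)OCCc1ccccn1` and compound 2 `Cc1cccc(NC(=S)OCCc2ccccn2)c1` share one core, while compound 3 `S=C(Nc1ccccc1)OCCc1ccccc1` differs from compound 1 in its core by phenyl in place of pyridin-2-yl on a saturated chain carbon, two bonds along the chain from an oxygen on an unsaturated carbon. In an ADME assay on MT4 cells (Homo sapiens) for cytotoxicity, read by MTT assay (a higher number here means that more compound is tolerated, a lower number that less compound is tolerated), compound 1 gives > 100000 nM, which is a limit of the assay. Compound 2 gives > 100000 nM, again a limit. Going by the values given here, compound 3 gives 100000 nM, the only number among the three. the limit of > 100000 nM in this assay, at which 2 of the 3 values shown sit. The step is a number no higher from compound 1 to compound 3 (the limit leaves the size open). The change methyl in place of hydrogen on an aromatic carbon gave a step that the two limits leave unreadable from compound 1 to compound 2. Compound 4 `Cc1ccc(NC(=S)OCCc2ccccc2)cc1` carries the same kind of change on the core of compound 3, (methyl in place of hydrogen on an aromatic carbon), the place being para to a large group rather than meta. The estimated step is no change at the digits printed from compound 3 to compound 4 (within the scatter); this rests on a step that the two limits leave unreadable from compound 1 to compound 2, which left no readable shift. Compound 4 is therefore expected at 100000 nM, between 45000 nM and 200000 nM.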

Compound 4, half-maximal cytotoxic concentration: > 100000 nM
Compound 4 ended at the assay's limit (the forecaster's own chance of this, stated with the estimate: 40%); the middle value lies on the limit itself.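

In this assay, the methyl change on the core of compound 3 gave a number no lower from compound 3 to compound 4 (the limit leaves the size open). Compound 4 gives > 100000 nM, which is a limit of the assay. The steps on both cores cannot be read in size, so the result shows no fall in the tolerated concentration on the core of compound 3, but it does not show that the change has the same size on the two cores: the limit of > 100000 nM in this assay, at which 3 of the 4 values shown sit.

From the compounds shown here alone, how an amine or a carboxylic acid in place of the methyl would read in this assay remains open. So does the effect of a longer chain between the oxygen and the ring on the far side of the shared core.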